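The compounds below may be only part of what the source reports. "The series", "measured", "known", "first", "only" and "open" are said of these compounds alone.

Compound 1, `COc1ccc(N(C)c2ccnc(Cl)n2)cc1`, gives 2120 nM in a functional assay on HepG2 cells (Homo sapiens) for antiproliferative activity, read by MTT assay, with a stated time of 48 h; a lower number here means a stronger inhibitor, a higher number a weaker inhibitor.
Compound 2, `COc1ccc(N(C)c2ccnc(Cl)n2)cc1F`, gives 844 nM.
Compound 3, `COc1ccc(N(C)c2ccnc(Cl)n2)cc1OCCCBr`, gives 1240 nM.

Among these three numbers compound 1 carries the largest; its gap to compound 3 is within the scatter, whereas the step of a 2.5-fold lower number from compound 1 to compound 2 (0.40 log units; beyond the scatter) is beyond it. Compound 4, `COc1ccc(N(C)c2ccnc(Cl)n2)cc1OCCCCCBr`, differs from compound 1 in one place: (5-bromopentyl)oxy in place of hydrogen on an aromatic carbon. Going by the values given here, the one measured step that bears directly on this change is a 1.7-fold lower number from compound 1 to compound 3 (0.23 log units; within the scatter), where a shorter chain of the same kind was put in at the same place and the number moved only within the scatter. The step of a 1.5-fold higher number from compound 2 to compound 3 (0.17 log units; within the scatter), also within the scatter, adds nothing against that picture. Among the compounds with values here, no measured pair shows what lengthening the chain by two carbons does. The step from compound 1 to compound 4 is therefore expected to be small, a slight lowering at most and perhaps none beyond the scatter: a 1.6-fold lower number from compound 1 to compound 4 (0.21 log units; within the scatter). The expected value for compound 4 is 1300 nM, with a range from 550 nM to 3000 nM.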

Compound 4, half-maximal inhibitory concentration: > 10000 nM
Compound 4: only a limit was reported; the forecaster's own chance of this, stated with the estimate: 3%; at least 7.6-fold (0.88 log units) between middle value and limit.
By their numbers in this assay, from the lowest: compounds 2, 3 and 1 (each within the scatter of the next, the first and the last beyond it). At a limit, above all of these: compound 4.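

The value for compound 4 is a limit of the assay and not a number: the limit of > 10000 nM in this assay, at which 1 of the 4 values shown sits. At this place on the aromatic ring, an added ether chain is therefore not always a small change: the step is an at least 4.7-fold higher number from compound 1 to compound 4 (0.67 log units; beyond the scatter), whereas compound 3 stays within the scatter of compound 1. Going by these compounds alone, the length of the chain matters here, which no earlier pair could show, with an at least 8.0-fold higher number from compound 3 to compound 4 (0.90 log units; beyond the scatter) for the longer chain alone and an at least 11-fold higher number from compound 2 to compound 4 (1.07 log units; beyond the scatter) when it takes the place of fluoro.

From the compounds shown here alone, it remains open what a pentyloxy chain without the bromine, or a chain ending in an amine or a carboxylic acid, would give. A 4-bromobutoxy chain would show whether the number rises gradually with length or sharply.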